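Moving the nitrile: cytotoxicity of a cyanophenyl isomer

This account rests on a few compounds, and the source may have more. Where it says the series, first, only, none or still open, it means among the compounds named here.

Compound 2 `N#Cc1ccc(-c2nc3c(NC4CCCC4)cccn3c2-c2ccnc(NC3CCCC3)n2)cc1` carries a nitrile on its outer aromatic ring. In an ADME assay on Vero cells (Chlorocebus sabaeus) for cytotoxicity (on this read-out higher numbers stand for lower toxicity in this test and lower numbers for higher toxicity in this test), compound 2 gives only a limit, > 40000 nM. Compound 1 `COc1ccc(-c2nc3c(NC4CCCC4)cccn3c2-c2ccnc(NC3CCCC3)n2)cc1`, the methoxy analogue, also reaches only a limit in this assay, > 10000 nM. Among the measured compounds shown here, the one measured step, a step that the two limits leave unreadable from compound 1 to compound 2, cannot be sized from two limits. Compound 3 `N#Cc1cccc(-c2nc3c(NC4CCCC4)cccn3c2-c2ccnc(NC3CCCC3)n2)c1` differs from compound 2 by 3-cyanophenyl in place of 4-cyanophenyl on an aromatic carbon. For the measured compounds named here, no measured step bears directly on this move, and both measured values are limits, so no direction beyond the scatter is indicated. Compound 3 is expected at 40000 nM, between 20000 nM and 80000 nM, a step of a number no higher from compound 2 to compound 3 (the limit leaves the size open) that is expected to stay within the scatter.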

Compound 3, half-maximal cytotoxic concentration: > 40000 nM
Compound 3 ended at the assay's limit; the forecaster's own chance of this, stated with the estimate: 80%; the middle value lies on the limit itself.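

Among the compounds shown here, compound 1, compound 2 and compound 3 all give only limits in this assay, so no step among them can be read. From the compounds shown here alone, whether 3-cyanophenyl and 4-cyanophenyl differ at all on this read-out stays open.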